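Swapping the outer ring of compound 1 for an acrylamide

The compounds below may be only part of what the source reports. "The series", "measured", "known", "first", "only" and "open" are said of these compounds alone.

Measured compounds and their values:
compound 1 `CCOc1cccc(-c2ccc(CN(C(=O)C3CCCCC3)c3cccc(/C=C/C(=O)OC)c3)cc2)c1` — 147 nM
compound 2 `CCOc1cccc(-c2ccc(CN(C(=O)C(C)C)c3cccc(/C=C/C(=O)OC)c3)cc2)c1` — 173 nM
compound 3 `COC(=O)/C=C/c1cccc(N(Cc2ccc(-c3ccc(N(C)C)cc3)cc2)C(=O)C(C)C)c1` — 57 nM

All three were tested in an assay on isolated protein with Bile acid receptor (Homo sapiens) as the target; a lower number here means that less compound is needed, a higher number that more compound is needed for the effect. Among the compounds with values here, compound 1 sits second highest of the three numbers: compound 2 lies within the scatter of it, as the step of a 1.2-fold higher number from compound 1 to compound 2 (0.07 log units; within the scatter) shows, while compound 3 is the one clearly lower value. Compound 4 `COC(=O)/C=C/c1cccc(N(Cc2ccc(/C=C/C(=O)N(C)C)cc2)C(=O)C2CCCCC2)c1` has not yet been measured. It differs from compound 1 in one place: 2-(dimethylcarbamoyl)ethenyl in place of 3-ethoxyphenyl on an aromatic carbon.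

Within the data shown here, none of the measured steps makes this exact change. Among the measured compounds shown here, the only step touching the same position is a 3.0-fold lower number from compound 2 to compound 3 (0.48 log units; beyond the scatter), where one six-membered ring replaced another; here the ring is lost altogether and a chain with a dimethylcarbamoyl group enters, which no measured pair covers. The step of a 1.2-fold higher number from compound 1 to compound 2 (0.07 log units; within the scatter) only shows that the cyclohexyl carbonyl of compound 1 behaves like an isopropyl one.

For the measured compounds named here, with no direct precedent, a modest rise in the number is expected for compound 4, estimated at 300 nM (range 100 nM to 1000 nM), which would mean a step of a 2.0-fold higher number from compound 1 to compound 4 (0.31 log units; beyond the scatter), though the range is wide.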

Compound 4, half-maximal effective concentration: > 1000 nM
Compound 4 was reported as a limit (the forecaster's own chance of this, stated with the estimate: 10%); middle value at least 3.3-fold (0.52 log units) away from the limit.
By their numbers in this assay, from the lowest: compound 3; then compounds 1 and 2 (each within the scatter of the next). At a limit, above all of these: compound 4.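

In this assay compound 4 gives > 1000 nM, which is a limit of the assay and not a number. Losing the aromatic ring at this position, as 3-ethoxyphenyl gives way to the 2-(dimethylcarbamoyl)ethenyl chain, brings an at least 6.8-fold higher number from compound 1 to compound 4 (0.83 log units; beyond the scatter), whereas the one earlier change here, a 3.0-fold lower number from compound 2 to compound 3 (0.48 log units; beyond the scatter), only exchanged one aromatic ring for another. This position is therefore not indifferent to what sits on it, and a change of this kind can raise the number well beyond the scatter, although the full size of the rise stays unknown: the limit of > 1000 nM in this assay, at which 1 of the 4 values shown sits.

The change removes the ring and brings in the amide at once, so the compounds shown cannot tell which of the two matters. A phenyl ring carrying a dimethylcarbamoyl group, or a simple alkyl chain with no amide, would help to separate these two effects.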